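This account rests on a few compounds, and the source may have more. Where it says the series, first, only, none or still open, it means among the compounds named here.

Working notes on the series. In a functional assay (aorta) with Rattus norvegicus as the target, in the presence of a further agent that is not named here (a higher number here means that more compound is needed for the effect, a lower number that less compound is needed), compound 1 `COC(=O)C1=C(C)N=C(C)/C(=C(\O)OC)C1c1cccc([N+](=O)[O-])c1` gives 3.4 nM. Compound 2 `COC(=O)C1=C(C)N=C(C)/C(=C(/O)OC)C1c1ccccc1OCc1c(C)no[n+]1[O-]` gives 78 nM, the higher of the two numbers and beyond the usual scatter from compound 1, so more of compound 2 is needed for the effect. Only these two values are available, and the two structures differ in more than one place, so their gap says nothing about any single change.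

The next compound to be read is compound 3 `COC(=O)C1=C(C)N=C(C)/C(=C(/O)OC)C1c1ccccc1OCc1no[n+]([O-])c1C#N`. Its difference from compound 2 is a group of 8 heavy atoms (3 carbon, 3 nitrogen, 2 oxygen; one five-membered aromatic ring with 3 hetero atoms) in place of a group of 7 heavy atoms (3 carbon, 2 nitrogen, 2 oxygen; one five-membered aromatic ring with 3 hetero atoms), on a saturated chain carbon bound to an oxygen on an aromatic ring. The exchange sits on a saturated chain carbon bound to an oxygen on an aromatic ring, and the rest of the structure stays the same.

Going by the values given here, no measured step covers this exchange, so the expectation starts from compound 2 at 78 nM and stays close to it. A modest move toward a lower number is expected, with no shift beyond the scatter: the estimate is a 1.4-fold lower number from compound 2 to compound 3 (0.15 log units; within the scatter). The range is kept wide for lack of a direct precedent. For compound 3 the expected value is 55 nM, with an estimated range of 15 nM to 200 nM.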

Compound 3, half-maximal effective concentration: 4.4 nM
Estimate against measurement, compound 3: 13-fold (1.10 log units) above, outside the stated range (below it).
By their numbers in this assay, from the lowest: compounds 1 and 3 (each within the scatter of the next); then compound 2.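

Going by these compounds alone, the first single-place step shows that this position, on a saturated chain carbon bound to an oxygen on an aromatic ring, is not indifferent to what it carries: in this assay there is an 18-fold lower number from compound 2 to compound 3 (1.25 log units; beyond the scatter), a large step. Both groups hold one five-membered aromatic ring with 3 hetero atoms, so an exchange that leaves that ring count unchanged and adds one heavy atom, with 1 triple bond outside aromatic rings, is enough to move the number well beyond the scatter. No measurement shown here bears on the origin of this step, so it stands as an observation without an explanation.

With one step, the result cannot be assigned to the nitrile alone or to the exchanged group as a whole, and it rests on a single pair with the rest of the structure held fixed. Going by these compounds, it also remains open where a carboxylic acid, an amine or a longer chain carried on the same ring would fall relative to compound 2 and compound 3 in this assay.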